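A few compounds are considered here, and "the series" means these few. Any claim that something is new, unique, unknown or untested is made for them only; others in the source may bear on it.

Compound 1 `Cc1cccc2c1nc(COc1ccc(Cl)cc1)n2CCCC1CCNCC1`: 335 nM
Compound 2 `CCCN1CCC(CCCn2c(COc3ccc(Cl)cc3)nc3c(C)cccc32)CC1`: 29 nM

Of the compounds shown here, two have so far been measured in an assay on AV12 cells for binding affinity to Neuropeptide Y receptor type 1 (Homo sapiens); on this read-out higher numbers stand for weaker inhibition and lower numbers for stronger inhibition. Compound 1 gives 335 nM, while compound 2 gives 29 nM, the lower of the two numbers. Going by the values given here, the single step between them, a 12-fold lower number from compound 1 to compound 2 (1.06 log units; beyond the scatter), came from putting propyl in place of hydrogen on an amine nitrogen in a ring.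

Compound 3 `Cc1cccc2c1nc(COc1ccc(Cl)cc1)n2CCCC1CCN(CCCc2ccccc2)CC1` has not yet been measured. It differs from compound 2 by phenyl in place of hydrogen on a saturated chain carbon, three bonds along the chain from an amine nitrogen in a ring. Among the compounds with values here, no measured step bears directly on this change. Within the data shown here, the one step known, a 12-fold lower number from compound 1 to compound 2 (1.06 log units; beyond the scatter), concerns substitution at the same amine nitrogen and shows that this part of the molecule can move the numbers strongly, but it tells nothing about extending the chain with a phenyl. The expected step of a 1.6-fold lower number from compound 2 to compound 3 (0.21 log units; within the scatter) is therefore kept modest. Compound 3 is expected to give about 18 nM, with a range from 6 nM to 60 nM.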

Compound 3, inhibition constant: 57 nM
The estimate for compound 3 lay 3.2-fold (0.50 log units) below the measured number; the measured number falls inside the stated range.
By their numbers in this assay, from the lowest: compounds 2 and 3 (each within the scatter of the next); then compound 1.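

The amine nitrogen in a ring tolerates a much larger group than propyl: in this assay, 3-phenylpropyl in place of hydrogen still gives a 5.9-fold lower number from compound 1 to compound 3 (0.77 log units; beyond the scatter) on the unsubstituted amine. Extending propyl to 3-phenylpropyl gives a 2.0-fold higher number from compound 2 to compound 3 (0.29 log units; within the scatter) so the added phenyl cannot be said to help or harm binding in this assay, and the two groups serve equally well within the precision of these measurements. No measured evidence is available to explain these numbers.

The compounds shown leave open how the length of the link to the ring matters, since benzyl or phenethyl on the same nitrogen could behave differently from 3-phenylpropyl. They also leave open whether a methoxy group on the phenyl, or a pyridine ring in its place, would move the number beyond the scatter.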